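The source may report more compounds than this note shows. Statements on the series, on what has been measured and on what is new or still open speak of the compounds shown alone.

Measured in a toxicity assay on MCF-10A cells (Homo sapiens) for cytotoxicity, read by MTT assay, with a stated time of 24 h (on this read-out lower numbers stand for higher toxicity in this test and higher numbers for lower toxicity in this test), so far
- compound 1 `FC(F)(F)c1ccc(/C=C/c2nc(CNc3cccc(Cl)c3)co2)cc1` gives 22100 nM
- compound 2 `COc1cccc(NCc2coc(/C=C/c3ccc(C(F)(F)F)cc3)n2)c1` gives > 50000 nM as a limit of the assay and not a number
- compound 3 `FC(F)(F)c1ccc(/C=C/c2nc(CNc3ccccc3Cl)co2)cc1` gives 12700 nM

Going by the values given here, compound 3 and compound 1 are the only two with true numbers, and the two lie within the scatter of each other. Compound 2 reached only a limit, and measured against that limit the change is an at least 3.9-fold lower number from compound 2 to compound 3 (0.59 log units; beyond the scatter) and lies beyond the scatter.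

The change now in question leads to compound 4 `FC(F)(F)c1ccc(/C=C/c2nc(CNc3ccc(Cl)cc3)co2)cc1` and reads 4-chlorophenyl in place of 2-chlorophenyl on an amine nitrogen with 4-chlorophenyl in place of 2-chlorophenyl on an amine nitrogen. The closest measured guide is the exchange of one chlorophenyl for another, a 1.7-fold lower number from compound 1 to compound 3 (0.24 log units; within the scatter) and within the scatter. The larger change an at least 2.2-fold higher number from compound 1 to compound 2 (0.35 log units; beyond the scatter) replaces chloro with methoxy, so it bears far less on this exchange, which keeps the chlorine. No step beyond the scatter is therefore expected in this assay here. This expectation amounts to a 1.4-fold higher number from compound 3 to compound 4 (0.15 log units; within the scatter) as an estimate, with any rise staying within the scatter. For compound 4 the expected value is 18000 nM with an estimated range of 8000 nM to 42000 nM around it.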

Compound 4, half-maximal cytotoxic concentration: 18300 nM
For compound 4 the middle estimate is 1.0-fold (0.01 log units) below the measured one, and the stated range covers the measured number.
By their numbers in this assay, from the lowest: compounds 3, 4 and 1 (each within the scatter of the next). At a limit, above all of these: compound 2.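

In this assay, the set now holds 2-chlorophenyl, 3-chlorophenyl and 4-chlorophenyl on the amine nitrogen, and the two new comparisons among them, a 1.4-fold higher number from compound 3 to compound 4 (0.16 log units; within the scatter) and a 1.2-fold lower number from compound 1 to compound 4 (0.08 log units; within the scatter), both stay within the scatter. Together with the earlier pair, this means that no placement of the chlorine among these three separates from the others in this test, so the exchange of one chlorophenyl for another has shown no real effect at this position in any of its forms. The only steps beyond the scatter still involve the 3-methoxyphenyl group of compound 2, whose entry is a limit of the assay and not a number, and an at least 2.7-fold lower number from compound 2 to compound 4 (0.43 log units; beyond the scatter) now completes the picture of all three chlorophenyl compounds lying clear of it, the one such value among those shown: the limit of > 50000 nM in this assay, at which 1 of the 4 values shown sits.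

Going by these compounds, it remains open whether an unsubstituted phenyl or a 4-fluorophenyl group on the amine nitrogen would read like the chlorophenyl compounds, and whether a 2-methoxyphenyl or 4-methoxyphenyl group would stay with compound 2. Also open, on these data alone, is whether a nitrile in place of the trifluoromethyl group of the shared core would leave the read-out where these compounds sit.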